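The source may report more compounds than this note shows. Statements on the series, on what has been measured and on what is new or still open speak of the compounds shown alone.

Measured compounds:
compound 1, `COc1ccc(-c2cc(/C=C/C(=O)c3ccc(N)cc3)[nH]n2)cc1`: 5410 nM
compound 2, `COc1ccc(C(=O)/C=C/c2cc(-c3cc(OC)c(OC)c(OC)c3)n[nH]2)cc1OC`: 2990 nM
compound 3, `COc1ccc(-c2cc(/C=C/C(=O)c3ccc(N)cc3)[nH]n2)cc1OC`: 6940 nM

All three values come from a functional assay on SW-620 cells (Homo sapiens) for inhibition, read by sulforhodamine B assay, with a stated time of 48 h; a lower number here means a stronger inhibitor of growth, a higher number a weaker inhibitor of growth. Compound 1 and compound 3 share one core and differ in a single place: methoxy in place of hydrogen on an aromatic carbon. In this assay the step is a 1.3-fold higher number from compound 1 to compound 3 (0.11 log units; within the scatter). Compound 2 is built on another core; the difference between the two cores is not broken down here. Its value and that of compound 1 lie within the scatter of each other, so no order is drawn between them, while the gap to compound 3 lies beyond it.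

Compound 4, `COc1cc(C(=O)/C=C/c2cc(-c3cc(OC)c(OC)c(OC)c3)n[nH]2)cc(OC)c1OC`, is not yet measured. Relative to compound 2 it carries methoxy in place of hydrogen on an aromatic carbon. The surroundings are not identical to those in compound 3, since the entering methoxy in compound 4 is also meta to a methoxy group; this is the same kind of change, not the same change. Going by the values given here, the only guide is the pair compound 1 to compound 3, whose step a 1.3-fold higher number from compound 1 to compound 3 (0.11 log units; within the scatter) stayed within the scatter. The expected step is therefore small, a 1.3-fold higher number from compound 2 to compound 4 (0.12 log units; within the scatter). The estimate for compound 4 in this assay is 3900 nM, with a likely range from 1500 nM to 10000 nM.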

Compound 4, concentration for total growth inhibition: 3080 nM
Compound 4: middle estimate off by 1.3-fold (0.10 log units), on the high side; the range from low to high includes it.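

In this assay, methoxy in place of hydrogen on an aromatic carbon gives a 1.0-fold higher number from compound 2 to compound 4 (0.01 log units; within the scatter). Set beside the earlier pair, the same kind of change reads alike on the two cores: the same change on two cores in this assay, a 1.3-fold higher number (0.11 log units; within the scatter) from compound 1 to compound 3 and a 1.0-fold higher number (0.01 log units; within the scatter) from compound 2 to compound 4, 1.2-fold (0.10 log units) apart, within the scatter of two such steps

Going by these compounds alone, this supports carrying the change between these two cores without expecting a step beyond the scatter, but it rests on only two pairs in one assay, and the entering methoxy does not have identical surroundings in compound 3 and compound 4, so it gives no rule for other cores or for other positions on these rings.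

Open, going by these compounds, is whether a larger or different group on the same aromatic carbon, such as ethoxy, hydroxyl or a fluorine atom, would give a step beyond the scatter. Also open, on these data alone, is how a carboxylic acid in place of the amino group of compound 1 and compound 3 would read in this assay.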